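Working notes: carbamoyl to carboxy, compound 3 to compound 4

The source may hold more compounds than are shown below. What is called first, only, known or untested is meant among the compounds shown, and "the series" means these compounds.

Among the measured compounds shown here, compound 3 `Cc1n[nH]c(C(=O)O)c1Cc1cccc(-c2ccc(C(N)=O)cc2)c1` carries the largest of the three numbers so far in an assay on isolated protein for inhibition of 2-Hydroxyacid oxidase 2 (Homo sapiens), tested at 1 uM (a higher number here means a stronger effect of the compound at the concentration tested, a lower number a weaker effect), at 18%. Compound 2 `Cc1n[nH]c(C(=O)O)c1Cc1cccc(-c2ccc(C#N)cc2)c1` gives 13%, and the step of a number 5 percentage points higher from compound 2 to compound 3 (within the scatter) is within the scatter, so no order between these two is claimed. Compound 1 `Cc1n[nH]c(C(N)=O)c1Cc1cccc(-c2ccc(F)cc2)c1` gives 1%, which lies beyond the scatter below compound 3.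

Compound 4 `Cc1n[nH]c(C(=O)O)c1Cc1cccc(-c2ccc(C(=O)O)cc2)c1` is not yet measured. It differs from compound 3 by hydroxy in place of amino on a carbonyl carbon. For the measured compounds named here, the only measured step that bears on this change is a number 5 percentage points higher from compound 2 to compound 3 (within the scatter), a change on the same aromatic carbon that stayed within the scatter; no measured step exchanges amino for hydroxy on a carbonyl carbon, so the expectation rests on that one step and on compound 3 at 18%. The step of no change at the digits printed from compound 3 to compound 4 (within the scatter) is therefore expected to be none beyond the scatter. Compound 4 is estimated at 18%, with a range from 5% to 32%.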

Compound 4, a percentage reported as inhibition, at one concentration (the size of the read-out at that concentration, not a potency): 3%
Compound 4: middle estimate off by 15 percentage points, on the high side; measured number below the stated range.
By their numbers in this assay, from the lowest: compounds 1, 4, 2 and 3 (each within the scatter of the next, the first and the last beyond it).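

Among the compounds shown here, on this aromatic carbon, the exchange of carbamoyl for carboxy gives the first step at this position beyond the scatter in this assay, with hydroxy in place of amino on a carbonyl carbon giving a number 15 percentage points lower from compound 3 to compound 4 (beyond the scatter). The other new step, a number 10 percentage points lower from compound 2 to compound 4 (within the scatter), lies within the scatter, so carboxy and cyano are not ordered here, and the position separates only carbamoyl from carboxy among the three groups compared. Nothing available explains this difference between two groups of the same size in heavy atoms.

Still open, as far as these compounds go, is how an aminomethyl, a methoxy or a sulfonamide on the same aromatic carbon would read in this assay. Compound 1 differs from the others in more than one place, so the carboxy on the shared core cannot be assessed separately from the group on the aromatic carbon.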